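Pyridin-3-yl in place of ethyl: compound 3

The compounds below may be only part of what the source reports. "The series", "measured", "known", "first", "only" and "open" are said of these compounds alone.

Measured compounds, with values from an ADME assay on MRC5 cells (Homo sapiens) for cytotoxicity, read by neutral red uptake, with a stated time of 24 h; a lower number here means a stronger inhibitor, a higher number a weaker inhibitor
- compound 1 `CCC(=O)Oc1c(C(C)C)cc2c3c1OC(=O)[C@@]31CCCC(C)(C)[C@@H]1CC2`: 125000 nM
- compound 2 `CCCCCCCC/C=C/CCCCCCCC(=O)Oc1c(C(C)C)cc2c3c1OC(=O)[C@@]31CCCC(C)(C)[C@@H]1CC2`: > 1000000 nM

Among the compounds with values here, compound 1 (125000 nM) holds the only number in the set. Compound 2 (> 1000000 nM) sits at a limit of the assay, and no number exists for it. Compound 3 (`CC(C)c1cc2c3c(c1OC(=O)c1cccnc1)OC(=O)[C@@]31CCCC(C)(C)[C@@H]1CC2`) is yet to be measured in this assay and carries pyridin-3-yl in place of ethyl on a carbonyl carbon. Within the data shown here, no measured step bears on this change. A small estimated step (a 1.3-fold higher number from compound 1 to compound 3 (0.11 log units; within the scatter)) towards weaker inhibition is expected, close to the scatter. For compound 3 the expected value is 160000 nM (estimated range 45000 nM to 600000 nM).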

Compound 3, half-maximal inhibitory concentration: 296000 nM
The estimate for compound 3 lay 1.9-fold (0.27 log units) below the measured number; the range from low to high includes it.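

Swapping ethyl for pyridin-3-yl on the carbonyl carbon gives the only readable step at this position in this assay, namely a 2.4-fold higher number from compound 1 to compound 3 (0.37 log units; beyond the scatter), towards weaker inhibition. The change is modest, and a six-membered aromatic ring with one hetero atom at this place still gives a measurable number. Compound 2 has a limit and not a number, so steps to it cannot be read: the limit of > 1000000 nM in this assay, at which 1 of the 3 values shown sits.

Still open, as far as these compounds go, is whether the shift comes from the ring nitrogen or from the aromatic ring itself, which a phenyl group on the same carbonyl carbon would separate. Also open, from the compounds shown here alone, is how a saturated chain such as hexyl would read here.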